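The source may report more compounds than this note shows. Statements on the series, on what has been measured and on what is new or still open speak of the compounds shown alone.

Measured compounds:
compound 1 `CC(=O)N[C@@H]1CCCc2c1cncc2N1CCc2cc(Cl)ccc2C1=O` 54 nM
compound 2 `CCC(=O)N[C@@H]1CCCc2c1cncc2N1C(=O)c2ccc(Cl)cc2[C@@H]1C` 6 nM
compound 3 `CC(=O)N[C@@H]1CCCc2c1cncc2N1C(=O)c2ccc(Cl)cc2[C@@H]1C` 4 nM

In an assay on cells for inhibition of cytochrome P450 11B2, mitochondrial (Homo sapiens), read by HTRF (on this read-out lower numbers stand for stronger inhibition and higher numbers for weaker inhibition), compound 1 gives the highest of the three numbers, while compound 2 and compound 3 lie far below it. Compound 1 and compound 3 share the same atoms joined differently; the difference between the two cores is not broken down here. Compound 3 and compound 2 differ by methyl in place of hydrogen on a saturated chain carbon bound to a carbonyl carbon, and this change produced a 1.5-fold higher number from compound 3 to compound 2 (0.18 log units; within the scatter). Compound 4 `CCC(=O)N[C@@H]1CCCc2c1cncc2N1CCc2cc(Cl)ccc2C1=O` has not yet been measured. It differs from compound 1 by methyl in place of hydrogen on a saturated chain carbon bound to a carbonyl carbon, the same change, at a place described in the same words. Because the earlier change gave a 1.5-fold higher number from compound 3 to compound 2 (0.18 log units; within the scatter), the step is expected to be a 1.2-fold higher number from compound 1 to compound 4 (0.08 log units; within the scatter), a small one. Compound 4 is therefore estimated at 65 nM, with a likely range of 25 nM to 160 nM.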

Compound 4, half-maximal inhibitory concentration: 119 nM
Compound 4: the middle estimate sits 1.8-fold (0.26 log units) below what was measured; the range from low to high includes it.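

In this assay, the change from acetamido to propanoylamino on the core of compound 1 gave a 2.2-fold higher number from compound 1 to compound 4 (0.34 log units; beyond the scatter). Set beside the earlier step, the size of the change does not differ measurably between the two cores: the same change on two cores in this assay, a 1.5-fold higher number (0.18 log units; within the scatter) from compound 3 to compound 2 and a 2.2-fold higher number (0.34 log units; beyond the scatter) from compound 1 to compound 4, 1.5-fold (0.17 log units) apart, within the scatter of two such steps. Among the compounds shown here, this shows that the change carried from one core to the other without a detectable difference, but it rests on only two steps and does not show that the same would hold on any other core.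

The compounds shown leave open how a longer chain, such as butanoyl, would compare with acetyl and propanoyl on either core. They also leave open the effect of a terminal amine or carboxylic acid on that chain.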